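The source may hold more compounds than are shown below. What is called first, only, known or untested is meant among the compounds shown, and "the series" means these compounds.

Three ureas on a shared core were measured in an assay on CHO-K1 cells for antagonist activity at transient receptor potential cation channel subfamily V member 1 (Homo sapiens), read by FLIPR and calcium flux, with a stated time of 6 min; a lower number here means a stronger inhibitor, a higher number a weaker inhibitor. Going by the values given here, compound 2 `Cn1ncc2c(NC(=O)NCc3cc(C(F)(F)F)nn3-c3ccc(F)cc3)cccc21` gives 8.4 nM, while compound 1 `Cn1ncc2c(NC(=O)NCc3cc(C(F)(F)F)nn3-c3ccc(Cl)cc3)cccc21` gives 2.7 nM; the single change between them, (chloro in place of fluoro on an aromatic carbon), produced a 3.1-fold lower number from compound 2 to compound 1 (0.49 log units; beyond the scatter). Compound 3 `Cn1ncc2c(NC(=O)NCc3cc(C(C)(C)C)nn3-c3ccc(F)c(F)c3)cccc21` has a different core, and the difference between the two cores is not broken down here; in this assay compound 3 gives 1 nM, the lowest of the three numbers. Compound 4 `Cn1ncc2c(NC(=O)NCc3cc(C(C)(C)C)nn3-c3ccc(F)c(Cl)c3)cccc21` is not yet measured. It differs from compound 3 by chloro in place of fluoro on an aromatic carbon, the same kind of change as from compound 2 to compound 1, though here the place is ortho to a fluoro group and meta to a large group rather than para to a large group. Resting on a 3.1-fold lower number from compound 2 to compound 1 (0.49 log units; beyond the scatter), compound 4 is expected to show a 2.0-fold lower number from compound 3 to compound 4 (0.30 log units; within the scatter), somewhat smaller than that earlier step. Compound 4 is therefore estimated at 0.5 nM. The expected range for compound 4 runs from 0.2 nM to 1.5 nM.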

Compound 4, inhibition constant: 0.6 nM
For compound 4 the middle estimate is 1.2-fold (0.08 log units) below the measured one; the measured number falls inside the stated range.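

In this assay, chloro in place of fluoro in going from 3,4-difluorophenyl to 3-chloro-4-fluorophenyl gives a 1.7-fold lower number from compound 3 to compound 4 (0.22 log units; within the scatter). Set beside the earlier step, this does not separate the two cores: the same change on two cores in this assay, a 3.1-fold lower number (0.49 log units; beyond the scatter) from compound 2 to compound 1 and a 1.7-fold lower number (0.22 log units; within the scatter) from compound 3 to compound 4, 1.9-fold (0.27 log units) apart, within the scatter of two such steps. The result is compatible with the change carrying over from one core to the other, but it rests on only two pairs, with the change at a different place on the ring in each, and the newer step alone cannot be told from scatter, so neither a constant size nor a dependence on the core is shown.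

The compounds shown leave open what a bromo, methyl or nitrile would do in place of that chloro. They also leave open whether an amine or a methoxy group there would fit the same picture.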